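Chloro for methoxy on a second aryl-piperazine core

A few compounds are considered here, and "the series" means these few. Any claim that something is new, unique, unknown or untested is made for them only; others in the source may bear on it.

Measured so far:
compound 1, `COc1cccc(N2CCN(CC(=O)N3CCN(c4nnc(-c5ccccc5)c(-c5ccccc5)n4)CC3)CC2)c1`, > 910000 nM
compound 2, `O=C(CN1CCN(c2cccc(Cl)c2)CC1)N1CCN(c2nnc(-c3ccccc3)c(-c3ccccc3)n2)CC1`, 56300 nM
compound 3, `COc1cccc(N2CCN(CC(=O)N3CCN(c4nnc(-c5ccc(C)cc5)c(-c5ccc(C)cc5)n4)CC3)CC2)c1`, 867000 nM

All three were run in a functional assay on MCF7 cells (Homo sapiens) for cytotoxicity, read by MTT assay, with a stated time of 24 h; on this read-out lower numbers stand for stronger inhibition and higher numbers for weaker inhibition. For compound 1 the value is a limit of the assay, not a number; it stands at the limit of > 910000 nM in this assay, at which 1 of the 3 values shown sits. Compound 2 differs from compound 1 by chloro in place of methoxy on an aromatic carbon, and this gave an at least 16-fold lower number from compound 1 to compound 2 (1.20 log units; beyond the scatter). Compound 3 carries the same methoxy group on a core that differs from that of compound 1; the difference between the two cores is not broken down here. Within this assay compound 3 gives 867000 nM, which beside compound 2 is a higher number.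

Compound 4, `Cc1ccc(-c2nnc(N3CCN(C(=O)CN4CCN(c5cccc(Cl)c5)CC4)CC3)nc2-c2ccc(C)cc2)cc1`, is not yet measured. Among the measured compounds shown here, it differs from compound 3 by chloro in place of methoxy on an aromatic carbon, the same change, at the same place, as the one from compound 1 to compound 2. If the change carries over to the second core, compound 4 is expected to show a 14-fold lower number from compound 3 to compound 4 (1.16 log units; beyond the scatter), on the strength of the step from compound 1 to compound 2 alone, which is the only earlier case of this change. For compound 4 the estimate is therefore 60000 nM, expected to fall between 15000 nM and 300000 nM.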

Compound 4, half-maximal inhibitory concentration: 797000 nM
The estimate for compound 4 lay 13-fold (1.12 log units) below the measured number; the measured number lies above the stated range.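

In this assay chloro in place of methoxy gave a 1.1-fold lower number from compound 3 to compound 4 (0.04 log units; within the scatter) so the large step seen on the core of compound 1 did not carry over to the core of compound 3: the same change on two cores in this assay, an at least 16-fold lower number (1.20 log units; beyond the scatter) from compound 1 to compound 2 and a 1.1-fold lower number (0.04 log units; within the scatter) from compound 3 to compound 4, at least 14-fold (1.17 log units) apart, beyond the scatter of two such steps
For compound 1 the value is a limit of the assay and not a number: the limit of > 910000 nM in this assay, at which 1 of the 4 values shown sits.
These two pairs show that the outcome of this change differs between the two cores, but they do not show which part of the difference between the cores matters, and they give no rule for any further core.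

Open, as far as these compounds go, is whether fluoro, trifluoromethyl or an amine on the same aromatic carbon would give a step beyond the scatter on both cores. Also open, from the compounds shown here alone, is whether a core carrying only one of the two methyl groups of compound 3 would follow the core of compound 1 or that of compound 3.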